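The compounds below may be only part of what the source reports. "The series", "measured", "known", "first", "only" and "open" are said of these compounds alone.

Compound 1 `OC[C@H]1O[C@@H](n2cnc3c(NCc4ccccc4F)ncnc32)[C@H](O)[C@@H]1O`: 33200 nM
Compound 2 `Cc1ccc(CNc2ncnc3c2ncn3[C@@H]2O[C@H](CO)[C@@H](O)[C@H]2O)cc1`: > 166000 nM (a limit, not a number)
Compound 3 `OC[C@H]1O[C@@H](n2cnc3c(NCc4ccc(F)cc4F)ncnc32)[C@H](O)[C@@H]1O`: 9600 nM

All three results come from a functional assay on K562 cells (Homo sapiens) for antiproliferative activity, with a stated time of 72 h; on this read-out lower numbers stand for stronger inhibition and higher numbers for weaker inhibition. Of the two true numbers, compound 3 holds the lower one, 9600 nM. Compound 4 `OC[C@H]1O[C@@H](n2cnc3c(NCc4ccc(F)c(F)c4F)ncnc32)[C@H](O)[C@@H]1O` changes compound 3 in one place: fluoro in place of hydrogen on an aromatic carbon. A fluoro replaces hydrogen on an aromatic carbon, ortho to two fluoro groups, turning 2,4-difluorophenyl into 2,3,4-trifluorophenyl. Among the compounds with values here, the one measured step of the same kind, a 3.5-fold lower number from compound 1 to compound 3 (0.54 log units; beyond the scatter), was modest. This single precedent is thin support, so a smaller modest gain is expected, and a result within the scatter remains possible. The expected change is a 1.6-fold lower number from compound 3 to compound 4 (0.20 log units; within the scatter). Compound 4 is estimated at 6000 nM, with an expected range of 2000 nM to 20000 nM.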

Compound 4, half-maximal inhibitory concentration: > 166000 nM
Compound 4: only a limit was reported (the forecaster's own chance of this, stated with the estimate: 5%); middle value at least 27-fold (1.44 log units) away from the limit.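

Fluoro in place of hydrogen is not a reliably helpful change on this ring: at the place ortho to two fluoro groups it gives an at least 17-fold higher number from compound 3 to compound 4 (1.23 log units; beyond the scatter), against a 3.5-fold lower number from compound 1 to compound 3 (0.54 log units; beyond the scatter) for the same kind of change elsewhere on the ring. Moving from the single fluoro to 2,3,4-trifluorophenyl also loses ground, with an at least 5.0-fold higher number from compound 1 to compound 4 (0.69 log units; beyond the scatter). Compound 4 gives only a limit, not a number, and compound 2 gives the same limit: the limit of > 166000 nM in this assay, at which 2 of the 4 values shown sit.

The step between compound 2 and compound 4 cannot be read. On these data alone, whether a chloro or methoxy group at this place would be tolerated stays open.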